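The compounds below may be only part of what the source reports. "The series", "measured", "known", "first", "only" and "open" are said of these compounds alone.

Compound 1, with the structure `CC(C)CCn1c(Cn2c(=O)n(C(C)C)c3ccccc32)nc2cc(CN)ccc21`, is one of three compounds tested for cytotoxicity in an ADME assay on HEp-2 cells (Homo sapiens) for cytotoxicity (a lower number here means that less compound is tolerated, a higher number that more compound is tolerated), where compound 1 gives 3920 nM. Of the three numbers, that of compound 1 is the second highest. Compound 3, with the structure `CC(C)CCn1c(Cn2c(=O)n(C)c3ccccc32)nc2cc(-c3nnn(C)n3)ccc21`, gives 2970 nM in this assay, a value within the usual scatter of that of compound 1, so the two cannot be told apart. Compound 2, with the structure `COCc1cccc2c1nc(Cn1c(=O)n(C(C)C)c3ccccc31)n2CCC(C)C`, gives 26700 nM in this assay, a higher number that lies beyond the scatter, meaning more of compound 2 is tolerated than of compound 1.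

Compound 4, with the structure `CC(C)CCn1c(Cn2c(=O)n(C(C)C)c3ccccc32)nc2cc(N)ccc21`, has not yet been measured. It differs from compound 1 in one place: amino in place of aminomethyl on an aromatic carbon. Going by the values given here, no measured pair in this set shows what this change does to cytotoxicity. A step of no more than the scatter is expected, in either direction, so the step of a 1.1-fold higher number from compound 1 to compound 4 (0.06 log units; within the scatter) is estimated to be small. Compound 4 is therefore expected to give about 4500 nM in this assay, within a range from 1500 nM to 13000 nM.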

Compound 4, half-maximal cytotoxic concentration: 32200 nM
Compound 4: middle estimate off by 7.2-fold (0.85 log units), on the low side; measured number outside the range, above it.
By their numbers in this assay, from the lowest: compounds 3 and 1 (each within the scatter of the next); then compounds 2 and 4 (each within the scatter of the next).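

In this assay, amino in place of aminomethyl on this aromatic carbon gives an 8.2-fold higher number from compound 1 to compound 4 (0.91 log units; beyond the scatter), so more of compound 4 is tolerated. Going by these compounds alone, this is the first pair in the set that differs in one place, and it shows that this position can move the number beyond the scatter, even though the change takes away only one carbon and leaves the counts of hydrogen-bond donors and acceptors and the net charge as they were. Nothing available here explains why this small change has such an effect. The compounds shown leave open how an aminoethyl chain, a hydroxyl or a carboxylic acid on the same aromatic carbon would compare with amino and aminomethyl. They also leave open whether the step would hold with a methyl group in place of the isopropyl group on the shared core.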